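A few compounds are considered here, and "the series" means these few. Any claim that something is new, unique, unknown or untested is made for them only; others in the source may bear on it.

Compound 1 `COc1ccc(C(=O)Nc2ccccc2F)cc1OC1CCCC1` was tested in an assay on isolated protein for inhibition of phosphodiesterase 4A (Sus scrofa) (on this read-out lower numbers stand for stronger inhibition and higher numbers for weaker inhibition), where compound 1 gives 10700 nM. Compound 2 `COc1ccc(C(=O)Nc2c(F)cccc2F)cc1` gives 37000 nM in this assay, a higher number and so a weaker inhibitor, beyond the usual scatter; compound 1 therefore stands lowest of the two numbers shown. Compound 3 `COc1ccc(C(=O)Nc2ccccc2Cl)cc1OC(=O)C1CCCC1` reached only a limit of this assay, (the limit of > 1000000 nM in this assay, at which 1 of the 3 values shown sits), so its result > 1000000 nM is not a number.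

Compound 4 `COc1ccc(C(=O)Nc2c(C)nsc2C)cc1OC1CCCC1` differs from compound 1 in one place: 3,5-dimethyl-1,2-thiazol-4-yl in place of 2-fluorophenyl on an amide-type nitrogen. Going by the values given here, no measured pair shows this exchange, so the size of the step is open. The step is expected to be small and toward weaker inhibition, a 1.7-fold higher number from compound 1 to compound 4 (0.23 log units; within the scatter), close to the scatter. Compound 4 is estimated at 18000 nM, with a likely range from 4000 nM to 90000 nM.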

Compound 4, half-maximal inhibitory concentration: 500 nM
The estimate for compound 4 lay 36-fold (1.56 log units) above the measured number, and the stated range ends above it.
By their numbers in this assay, from the lowest: compound 4; then compound 1; then compound 2. At a limit, above all of these: compound 3.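

In this assay, the group on the amide-type nitrogen proves to be a strong lever on inhibition: 3,5-dimethyl-1,2-thiazol-4-yl in place of 2-fluorophenyl gives a 21-fold lower number from compound 1 to compound 4 (1.33 log units; beyond the scatter). The position therefore accepts a five-membered aromatic ring with 2 hetero atoms in place of a six-membered aromatic ring of carbon only, and inhibition improves. Nothing measured here explains the size of this step.

From the compounds shown here alone, whether the ring itself or its two methyl groups carry the gain stays open. Equally open, going by these compounds, is how a pyridine ring or a carboxylic acid would fare at this position.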